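A Fluoro to Trifluoromethyl Swap on an Anilino Sulfone

The compounds below may be only part of what the source reports. "The series", "measured", "known", "first", "only" and "open" are said of these compounds alone.

Among the measured compounds shown here, compound 2 `Cc1ccc(S(=O)(=O)c2nc3ccccc3nc2Nc2ccc(F)cc2)cc1` is the only compound here with a number in a functional assay on HCT-116 cells (Homo sapiens) for cytotoxicity, read by MTT assay, with a stated time of 72 h (a lower number here means a stronger inhibitor, a higher number a weaker inhibitor), where compound 2 gives 10500 nM. Compound 1 `COc1ccc(Nc2nc3ccccc3nc2S(=O)(=O)c2ccc(C)cc2)cc1` gives in this assay only a limit, > 50000 nM. Compound 3 `Cc1ccc(S(=O)(=O)c2nc3ccccc3nc2Nc2ccc(C(F)(F)F)cc2)cc1` differs from compound 2 by trifluoromethyl in place of fluoro on an aromatic carbon. For the measured compounds named here, the single measured step that bears on this change is an at least 4.7-fold lower number from compound 1 to compound 2 (0.67 log units; beyond the scatter), a downward step of at least modest size that sits against (the limit of > 50000 nM in this assay, at which 1 of the 2 values shown sits). A smaller downward step is therefore expected, a 1.8-fold lower number from compound 2 to compound 3 (0.24 log units; within the scatter). Compound 3 is accordingly estimated at 6000 nM, with a range from 2000 nM to 25000 nM.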

Compound 3, half-maximal inhibitory concentration: 950 nM
Compound 3: the middle estimate sits 6.3-fold (0.80 log units) above what was measured; the measured number lies below the stated range.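

Among the compounds shown here, replacing fluoro with trifluoromethyl at this aromatic carbon gives an 11-fold lower number from compound 2 to compound 3 (1.04 log units; beyond the scatter) in this assay, so this position responds more strongly than the earlier compounds indicated. Set against methoxy, the same group gives an at least 52-fold lower number from compound 1 to compound 3 (1.72 log units; beyond the scatter). That step has no fixed size, as compound 1 gives only a limit: the limit of > 50000 nM in this assay, at which 1 of the 3 values shown sits. The compounds shown leave open whether this drop is particular to trifluoromethyl or would also follow from a nitrile, a chlorine or a carboxylic acid at this carbon. They also leave open whether the swap acts alike when the sulfone is replaced by an amide.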